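This account rests on a few compounds, and the source may have more. Where it says the series, first, only, none or still open, it means among the compounds named here.

Three analogues of a shared core have been measured in an ADME assay on HeLa cells (Homo sapiens) for cytotoxicity, read by MTT assay, with a stated time of 72 h; a higher number here means that more compound is tolerated, a lower number that less compound is tolerated. Compound 1 `Clc1ccc(/C=N/c2sc3c(c2-c2nc4ccccc4s2)CCCC3)cc1` gives 431 ug/mL. Compound 2 `Fc1ccccc1/C=N/c1sc2c(c1-c1nc3ccccc3s1)CCCC2` gives 426 ug/mL. Compound 3 `FC(F)(F)c1ccc(/C=N/c2sc3c(c2-c2nc4ccccc4s2)CCCC3)cc1` gives 369 ug/mL. The steps of a 1.2-fold lower number from compound 1 to compound 3 (0.07 log units; within the scatter) and a 1.2-fold lower number from compound 2 to compound 3 (0.06 log units; within the scatter) both stay within the scatter, as does a 1.0-fold lower number from compound 1 to compound 2 (0.01 log units; within the scatter), so the group on the carbon with a double bond to nitrogen has so far made no difference that can be read. Compound 4 `Oc1ccccc1/C=N/c1sc2c(c1-c1nc3ccccc3s1)CCCC2` carries 2-hydroxyphenyl in place of 4-(trifluoromethyl)phenyl on a carbon with a double bond to nitrogen. Among the compounds with values here, no measured step covers 2-hydroxyphenyl, so the expectation rests only on the three flat steps. On that basis the expected step is a 1.1-fold higher number from compound 3 to compound 4 (0.04 log units; within the scatter), nothing beyond the scatter. Compound 4 is estimated at 400 ug/mL, with a range from 250 ug/mL to 620 ug/mL.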

Compound 4, half-maximal cytotoxic concentration: 122 ug/mL
For compound 4 the middle estimate is 3.3-fold (0.52 log units) above the measured one; the measured number lies below the stated range.
By their numbers in this assay, from the lowest: compound 4; then compounds 3, 2 and 1 (each within the scatter of the next).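

In this assay the group on the carbon with a double bond to nitrogen now makes a readable difference: 2-hydroxyphenyl gives a 3.0-fold lower number from compound 3 to compound 4 (0.48 log units; beyond the scatter) and a 3.5-fold lower number from compound 1 to compound 4 (0.55 log units; beyond the scatter) against the two other aryl groups. The closest pair, hydroxy in place of fluoro on an aromatic carbon, gives a 3.5-fold lower number from compound 2 to compound 4 (0.54 log units; beyond the scatter) and shows that this one change is enough to separate compound 4 from the flat trio. Nothing available explains the shift. Whether it is specific to hydroxy stays open, as the compounds shown include no methoxy or amino group on that phenyl ring.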